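Isopropoxy in Place of Cyclohexyl at the Amide Carbonyl

The source may report more compounds than this note shows. Statements on the series, on what has been measured and on what is new or still open speak of the compounds shown alone.

Compound 3 `Cc1cc(NC(=O)C2CCCCC2)nn1Cc1cc(Cl)ccc1OCC(C)C` gives 31.6 nM in an assay on CHO-K1 cells for displacement of a labelled ligand from prostaglandin E2 receptor EP1 subtype (Homo sapiens) (a higher number here means a weaker inhibitor, a lower number a stronger inhibitor), the second highest of the three numbers shown. Compound 1 `Cc1cc(C(N)=O)nn1Cc1cc(Cl)ccc1OCC(C)C` gives 126 nM, and compound 2 `Cc1cc(NC(=O)c2c(F)cccc2F)nn1Cc1cc(Cl)ccc1OCc1ccccc1` gives 12.6 nM. Compound 4 `Cc1cc(NC(=O)OC(C)C)nn1Cc1cc(Cl)ccc1OCC(C)C` differs from compound 3 by isopropoxy in place of cyclohexyl on a carbonyl carbon. Within the data shown here, the one measured single-point step, a 4.0-fold lower number from compound 1 to compound 3 (0.60 log units; beyond the scatter), concerns a different change at the amide and offers no direct guide to swapping the group on the carbonyl carbon; no measured pair exchanges a cyclohexyl for an isopropoxy. A step of at most modest size, in either direction, is therefore expected, a 1.6-fold higher number from compound 3 to compound 4 (0.20 log units; within the scatter). Compound 4 is expected to give about 50 nM in this assay, within a range of 15 nM to 160 nM.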

Compound 4, half-maximal inhibitory concentration: 50.1 nM
Compound 4: the middle estimate sits 1.0-fold (0.00 log units) below what was measured, and the stated range covers the measured number.
By their numbers in this assay, from the lowest: compound 2; then compounds 3 and 4 (each within the scatter of the next); then compound 1.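

In this assay the step of a 1.6-fold higher number from compound 3 to compound 4 (0.20 log units; within the scatter) lies within the scatter, so on this carbonyl carbon the ring-free isopropoxy, with its one hydrogen-bond acceptor, stands level with cyclohexyl. The step of a 2.5-fold lower number from compound 1 to compound 4 (0.40 log units; beyond the scatter) lies beyond the scatter, so (isopropoxycarbonyl)amino, like (cyclohexylcarbonyl)amino, keeps a lower number than carbamoyl on the aromatic carbon. Nothing shown here offers a reason for these numbers. Still open, from the compounds shown here alone, is whether a methoxy, a tert-butoxy or a dimethylamino group on the same carbonyl carbon would hold the number. Also open, going by these compounds, is whether the exchange reads the same with the ether of compound 2 on the shared core.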